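Methanesulfonamide-bearing anilinopyrimidines: antiproliferative notes

The source may hold more compounds than are shown below. What is called first, only, known or untested is meant among the compounds shown, and "the series" means these compounds.

Measured so far:
compound 1 `CN(c1cccc2c1CN(c1nc(Nc3ccc(C(F)(F)F)cc3)ncc1C(F)(F)F)C2)S(C)(=O)=O` – > 30000 nM
compound 2 `CN(c1cccc2c1CN(c1nc(Nc3cccc(C(F)(F)F)c3)ncc1C(F)(F)F)C2)S(C)(=O)=O` – > 30000 nM
compound 3 `COc1cc(N2CCN(C(C)=O)CC2)ccc1Nc1ncc(C(F)(F)F)c(N2Cc3cccc(N(C)S(C)(=O)=O)c3C2)n1` – 4700 nM

In a functional assay on U-87MG ATCC cells for antiproliferative activity against U-87 MG (Homo sapiens), read by spectrophotometry, with a stated time of 2 days (a lower number here means a stronger inhibitor of growth, a higher number a weaker inhibitor of growth), compound 1 returns only a limit, > 30000 nM. Compound 2 likewise returns a limit, > 30000 nM. The step that the two limits leave unreadable from compound 1 to compound 2 therefore cannot be read. For the measured compounds named here, compound 3 is the one compound of the three with a number, 4700 nM. That number lies on the side of stronger growth inhibition with respect to the limit of > 30000 nM in this assay, at which 2 of the 3 values shown sit.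

Compound 4 `COc1cc(Nc2ncc(C(F)(F)F)c(N3Cc4cccc(N(C)S(C)(=O)=O)c4C3)n2)cc(C(F)(F)F)c1` is not yet measured. It differs from compound 1 as follows: 3-methoxy-5-(trifluoromethyl)phenyl in place of 4-(trifluoromethyl)phenyl on a nitrogen on an aromatic ring. Going by the values given here, no measured step matches this change; the only step on the same nitrogen, a step that the two limits leave unreadable from compound 1 to compound 2, is unreadable. Compound 3 shows that a substituted aryl at this position can give a number inside the assay range, but its aryl is not the one entering here. The expected step of an at least 1.2-fold lower number from compound 1 to compound 4 (0.07 log units; that floor lies within the scatter) is therefore small and uncertain in direction, with a real chance that compound 4 again reports only a limit. For compound 4 the estimate in this assay is 25000 nM, with a range from 5000 nM to 60000 nM.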

Compound 4, concentration for 50% growth inhibition: > 30000 nM
Compound 4: only a limit was reported; the forecaster's own chance of this, stated with the estimate: 55%; middle value at least 1.2-fold (0.07 log units) from the limit.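

Compound 4 returns only a limit in this assay, > 30000 nM. Compound 1 and compound 2 are also limits, so the steps from either to compound 4 cannot be read. The compounds shown leave open how far changing the aryl group on this nitrogen shifts growth inhibition.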